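The source may hold more compounds than are shown below. What is called first, only, known or untested is meant among the compounds shown, and "the series" means these compounds.

Compound 1 `O=C(Nc1cccc(-n2cc(-c3ccncc3)c(-c3ccc(Cl)c(O)c3)n2)c1)Nc1cccc(C(F)(F)F)c1` gives in a functional assay on UO-31 cells (Homo sapiens) for inhibition, read by sulforhodamine B assay, with a stated time of 48 h (a higher number here means a weaker inhibitor of growth, a lower number a stronger inhibitor of growth), the reading > 32500 nM, which is a limit of the assay and not a number.
Compound 2 `COc1cc(-c2nn(-c3cccc(NC(=O)Nc4ccc(Cl)c(Cl)c4)c3)cc2-c2ccncc2)ccc1Cl` gives in this assay the value 4980 nM.

Within the data shown here, compound 2 therefore stands as the only compound of the two with a numerical reading in this assay; the other reading is the limit of > 32500 nM in this assay, at which 1 of the 2 values shown sits. Compound 3 `O=C(Nc1cccc(-n2cc(-c3ccncc3)c(-c3ccc(Cl)c(O)c3)n2)c1)Nc1ccc(Cl)c(Cl)c1` differs from compound 2 in a single place: hydrogen in place of methyl on an oxygen on an aromatic ring, so that methoxy becomes hydroxy and 4-chloro-3-methoxyphenyl becomes 4-chloro-3-hydroxyphenyl. Among the measured compounds shown here, no pair of measured compounds is separated by this change alone, so the size of the step cannot be read from the data directly. For the measured compounds named here, the one hydroxy-bearing compound that has been measured, compound 1, gives > 32500 nM, a limit of the assay. Against that background a loss of growth inhibition beyond the usual scatter is expected in this assay from compound 2 to compound 3 a 3.0-fold higher number from compound 2 to compound 3 (0.48 log units; beyond the scatter), with considerable uncertainty. Compound 3 is accordingly estimated at 15000 nM, within a range of 5000 nM to 40000 nM.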

Compound 3, concentration for total growth inhibition: > 32500 nM
Compound 3 was reported as a limit; the forecaster's own chance of this, stated with the estimate: 30%; middle value at least 2.1-fold (0.33 log units) away from the limit.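

In this assay, the change from methoxy to hydroxy on the 4-chloro-3-methoxyphenyl group gives an at least 6.5-fold higher number from compound 2 to compound 3 (0.81 log units; beyond the scatter), so this position responds to the loss of a single methyl by more than the usual scatter. Compound 3 gives > 32500 nM, which is a limit of the assay, so the step has a lower bound but no full size. Compound 1 and compound 3 differ only in 3,4-dichlorophenyl in place of 3-(trifluoromethyl)phenyl on an amide-type nitrogen, the step between them cannot be read, and with hydroxy in place neither of these groups gives a numerical reading: the limit of > 32500 nM in this assay, at which 2 of the 3 values shown sit.

The compounds shown leave open how far the reading would move with an ethoxy group or a longer chain on the same oxygen, or with an amine in place of the oxygen substituent. They also leave open whether methoxy would give a numerical reading alongside 3-(trifluoromethyl)phenyl, and so whether the effect of this change holds with a different group on the amide-type nitrogen.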